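The source may hold more compounds than are shown below. What is called first, only, known or untested is meant among the compounds shown, and "the series" means these compounds.

Measured so far, in a functional assay on DU-145 cells (Homo sapiens) for inhibition, read by trypan blue exclusion, with a stated time of 96 h; a lower number here means a stronger inhibitor of growth, a higher number a weaker inhibitor of growth:
compound 1, `Cc1ccc(C)c(/C=C(/Sc2ccc(Br)cc2)C(=O)c2ccc(Cl)cc2)c1`, gives 10000 nM
compound 2, `Cc1ccc(CS/C(=C/c2cc(C)ccc2C)C(=O)c2ccc(Cl)cc2)cc1`, gives 10000 nM
compound 3, `COc1ccc(/C=C(\C(=O)c2ccc(Cl)cc2)S(=O)(=O)c2ccc(Br)cc2)cc1`, gives 10000 nM

Within the data shown here, compound 2 stands level with compound 1 and compound 3 in this assay; the three values lie within the scatter of one another, so no compound can be set above another here. Among the measured compounds shown here, the one change that can be read as a step is that from compound 1 to compound 2, where 4-methylbenzyl takes the place of 4-bromophenyl on a sulfur, and that step is no change at the digits printed from compound 1 to compound 2 (within the scatter).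

Compound 4, `Cc1ccc(CS/C(=C/c2sccc2C)C(=O)c2ccc(Cl)cc2)cc1`, is not yet measured in this assay. It differs from compound 2 in one place: 3-methylthiophen-2-yl in place of 2,5-dimethylphenyl on a double-bonded chain carbon bound to a double-bonded chain carbon. For the measured compounds named here, no measured step bears directly on this exchange of one aromatic ring for another on the double-bonded chain carbon. Going by the values given here, the only measured step, no change at the digits printed from compound 1 to compound 2 (within the scatter), touches a different part of the shared core and showed nothing beyond the scatter, and all three measured compounds sit at the same weak level. On this footing the step from compound 2 to compound 4 is expected to be no change at the digits printed from compound 2 to compound 4 (within the scatter), with no direction beyond the scatter. Compound 4 is therefore estimated at 10000 nM, with a range from 5000 nM to 20000 nM.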

Compound 4, concentration for 50% growth inhibition: 10000 nM
Estimate against measurement, compound 4: no gap at the digits printed; the range from low to high includes it.
By their numbers in this assay, from the lowest: compounds 1, 2, 3 and 4 (each within the scatter of the next).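

In this assay, among these compounds, the exchange of 2,5-dimethylphenyl for 3-methylthiophen-2-yl on a double-bonded chain carbon bound to a double-bonded chain carbon gives no change at the digits printed from compound 2 to compound 4 (within the scatter) and is the only measured step at this position. The earlier step concerned the group on sulfur, so this one adds that a six-membered carbon ring and a five-membered ring with one sulfur give the same reading here, though at a level where all four compounds sit together and with no sign yet that this position can shift the value. Nothing measured explains this flat result.

From the compounds shown here alone, it remains open whether any group at this position can separate one compound from another. An aminomethyl or a carboxylic acid on this ring, or a pyridine ring in its place, would put that to the test.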